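Bromo in place of fluoro: compound 3 to compound 4

A few compounds are considered here, and "the series" means these few. Any claim that something is new, unique, unknown or untested is made for them only; others in the source may bear on it.

In a functional assay on MDA-MB-231 cells (Homo sapiens) for antiproliferative activity, read by MTT assay, with a stated time of 72 h (on this read-out lower numbers stand for stronger inhibition and higher numbers for weaker inhibition), compound 1 `CCNC(=O)CCc1cccc2c1B(O)OC2` gives > 100000 nM, which is a limit of the assay and not a number. Compound 2 `O=C(CCc1cccc2c1B(O)OC2)Nc1ccccc1` gives 230 nM and compound 3 `O=C(CCc1cccc2c1B(O)OC2)Nc1ccc(F)cc1` gives 440 nM. Going by the values given here, compound 3 therefore stands level with its only numeric neighbour, as a 1.9-fold higher number from compound 2 to compound 3 (0.28 log units; within the scatter) lies within the scatter.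

Compound 4 `O=C(CCc1cccc2c1B(O)OC2)Nc1ccc(Br)cc1` carries one change: bromo in place of fluoro on an aromatic carbon. In words, this is bromo in place of fluoro on an aromatic carbon, para to a large group.

The closest measured precedent is the halogen step on the same ring, a 1.9-fold higher number from compound 2 to compound 3 (0.28 log units; within the scatter). The large steps, an at least 430-fold lower number from compound 1 to compound 2 (2.63 log units; beyond the scatter) and an at least 220-fold lower number from compound 1 to compound 3 (2.35 log units; beyond the scatter), exchange ethyl for an aromatic ring, a far bigger change, and bear on this swap only by showing that the aromatic ring matters. No step beyond the scatter is therefore expected in this assay, and no firm direction. The estimated step is a 1.3-fold lower number from compound 3 to compound 4 (0.10 log units; within the scatter). For compound 4 the estimated value is 350 nM, with an expected range from 120 nM to 1000 nM.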

Compound 4, half-maximal inhibitory concentration: 5300 nM
Beside the measured number, compound 4's estimate is 15-fold (1.18 log units) below it; the whole stated range lies below it.
By their numbers in this assay, from the lowest: compounds 2 and 3 (each within the scatter of the next); then compound 4. At a limit, above all of these: compound 1.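

In this assay, the place para to a large group is sensitive to which halogen it carries: fluoro left the number level with hydrogen, with a 1.9-fold higher number from compound 2 to compound 3 (0.28 log units; within the scatter), whereas bromo gives a 12-fold higher number from compound 3 to compound 4 (1.08 log units; beyond the scatter) and a 23-fold higher number from compound 2 to compound 4 (1.36 log units; beyond the scatter). The aromatic ring on the amide-type nitrogen still holds an advantage over ethyl with bromo in place, with an at least 18-fold lower number from compound 1 to compound 4 (1.27 log units; beyond the scatter). Compound 1 stands at a limit of the assay and not a number, so that last step is only a bound: the limit of > 100000 nM in this assay, at which 1 of the 4 values shown sits.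

The data give no cause for the rise with bromo, and what chloro, iodo or methoxy at this same place would give stays open. Also open, from the compounds shown here alone, are an amine on this ring and a longer chain on the amide-type nitrogen in place of ethyl.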